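Methyl-to-hydrogen change on the chromone core of compound 2

The source may hold more compounds than are shown below. What is called first, only, known or untested is meant among the compounds shown, and "the series" means these compounds.

Compound 2 `CCCCCCCCCCCCCCCc1cc(=O)c2c(O)c(C)c(OCOC)c(C)c2o1` is the reference point here. In a functional assay on MDA-MB-231 cells (Homo sapiens) for antiproliferative activity, read by MTT assay (on this read-out lower numbers stand for stronger inhibition and higher numbers for weaker inhibition), compound 2 gives only a limit, > 87000 nM, and no number. Compound 1 `CCCC/C=C\CCCCCCCCCc1cc(=O)c2c(O)cc(OCOC)c(C)c2o1` likewise gives only a limit in this assay, > 87000 nM. Going by the values given here, compound 3 `CC/C=C\C/C=C\C/C=C\CCCCCCCc1cc(=O)c2c(O)c(C)c(OCOC)c(C)c2o1` is the one member with a number, 16100 nM; the step of an at least 5.4-fold lower number from compound 2 to compound 3 (0.73 log units; beyond the scatter) concerns the chain only and says nothing about the aromatic core. Two of the three measured values sit at the same limit (the limit of > 87000 nM in this assay, at which 2 of the 3 values shown sit).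

Compound 4 `CCCCCCCCCCCCCCCc1cc(=O)c2c(O)cc(OCOC)c(C)c2o1` is the unmeasured compound. It differs from compound 2 by hydrogen in place of methyl on an aromatic carbon. Among the compounds with values here, no measured step alters the core in this way, so there is nothing to set the size of the expected change; the only related point is compound 1, which shares the hydrogen at that position and also sits at the limit. Compound 4 is therefore expected to stay at or beyond the limit, with the step that the limit leaves unreadable from compound 2 to compound 4 estimated as nothing beyond the scatter. The estimate for compound 4 is 150000 nM, within a range from 60000 nM to 400000 nM, with a high chance that this assay again reports only a limit.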

Compound 4, half-maximal inhibitory concentration: > 87000 nM
Compound 4 ended at the assay's limit; the forecaster's own chance of this, stated with the estimate: 85%; the middle value does not contradict the limit.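

In this assay compound 4 gives > 87000 nM, a limit and not a number. Compound 1 and compound 2 also stand at limits, so neither step, from compound 2 to compound 4 or from compound 1 to compound 4, can be read. What hydrogen in place of methyl does on the aromatic carbon remains open, since the compounds shown include no such pair with a numerical value.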